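The compounds below may be only part of what the source reports. "The series", "measured", "known", "first", "only" and "open" are said of these compounds alone.

Compound 1, `COc1nc2ccc(Br)cc2cc1C(c1ccccc1)n1cc(-c2ccccc2F)nn1`, was tested in an ADME assay on PANC-1 cells (Homo sapiens) for cytotoxicity, read by sulforhodamine B assay, with a stated time of 48 h, tested at 10 uM (on this read-out higher numbers stand for more inhibition at the one concentration tested (going by the name of the read-out) and lower numbers for less inhibition), and gives 14.7%. On the numbers shown it holds the highest of three values, yet neither of the other two is separated from it by more than the usual scatter of this kind of measurement. Compound 2, `CCCCCCCCc1cn(C(c2ccccc2)c2cc3cc(Br)ccc3nc2OC)nn1`, gives 12.1% in this assay, and compound 3, `COc1nc2ccc(Br)cc2cc1C(c1ccccc1)n1cc(-c2ccc(OC(F)(F)F)cc2)nn1`, gives 11.7%.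

Compound 4, `COc1nc2ccc(Br)cc2cc1C(c1ccccc1)n1cc(C2CC2)nn1`, has not been measured yet. It differs from compound 1 at one place: cyclopropyl in place of 2-fluorophenyl on an aromatic carbon. Two measured steps change the same position of the shared core, and both stay small: a number 2.6 percentage points lower from compound 1 to compound 2 (within the scatter) and a number 3 percentage points lower from compound 1 to compound 3 (within the scatter). Swapping the 2-fluorophenyl for either a long chain or another ring has so far left the read-out in this assay essentially unchanged, so a change to cyclopropyl at the same position is expected to behave likewise, with no step beyond the scatter in either direction.

For compound 4 the expected step is a number 1.7 percentage points lower from compound 1 to compound 4 (within the scatter), giving an estimated value of 13% in this assay, within a range from 3% to 23%.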

Compound 4, a percentage reported as inhibition, at one concentration (the size of the read-out at that concentration, not a potency): 21.8%
The estimate for compound 4 lay 8.8 percentage points below the measured number; low and high end bracket the measured number.
By their numbers in this assay, from the lowest: compounds 3, 2, 1 and 4 (each within the scatter of the next, the first and the last beyond it).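

Going by these compounds alone, the position is not wholly silent in this assay: cyclopropyl in place of 4-(trifluoromethoxy)phenyl gives a number 10.1 percentage points higher from compound 3 to compound 4 (beyond the scatter), the first step at this aromatic carbon to pass the scatter. The other two steps, a number 7.1 percentage points higher from compound 1 to compound 4 (within the scatter) and a number 9.7 percentage points higher from compound 2 to compound 4 (within the scatter), stay within it, so compound 4 stands apart from compound 3 alone, and only modestly. Nothing available gives a reason for this step.

As far as these compounds go, whether the higher number belongs to cyclopropyl alone or to small groups more widely stays open. A cyclobutyl ring, a short chain such as ethyl, or an amine at this same aromatic carbon would show whether the read-out follows group size or something particular to the three-membered ring.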